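Fluoro Addition Across Two Cores in Rat Cell Cytotoxicity

The source may report more compounds than this note shows. Statements on the series, on what has been measured and on what is new or still open speak of the compounds shown alone.

Compound 1 `OC(c1ccc(Cl)cc1)(c1ccc(C(F)(F)F)cc1)c1cccnc1` was tested in an ADME assay on L6 cells (Rattus norvegicus) for cytotoxicity, read by resazurin assay, with a stated time of 72 h (a lower number here means a stronger inhibitor, a higher number a weaker inhibitor), where compound 1 gives 56400 nM. Compound 2 `OC(c1ccc(C(F)(F)F)cc1)(c1cccnc1)c1ccc(Cl)cc1F` differs from it by fluoro in place of hydrogen on an aromatic carbon. In this assay compound 2 reaches only a limit of the assay, > 100000 nM. That step is an at least 1.7-fold higher number from compound 1 to compound 2 (0.24 log units; that floor lies within the scatter). Compound 3 `CC(C)Oc1ncc(C(O)(c2ccc(Cl)cc2)c2cccnc2)cn1` is built on another core; the difference between the two cores is not broken down here. In this assay compound 3 also gives only a limit, > 100000 nM. Compound 4 `CC(C)Oc1ncc(C(O)(c2cccnc2)c2ccc(Cl)cc2F)cn1` carries the same change, (fluoro in place of hydrogen on an aromatic carbon). In this assay the step is expected to be a step that the limit leaves unreadable from compound 3 to compound 4, set beside the measured one, because compound 3 already sits at the limit of > 100000 nM in this assay, at which 2 of the 3 values shown sit, and because an at least 1.7-fold higher number from compound 1 to compound 2 (0.24 log units; that floor lies within the scatter) did not lower the number. Compound 4 is therefore estimated at 150000 nM, expected to lie between 100000 nM and 300000 nM.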

Compound 4, half-maximal inhibitory concentration: 89500 nM
The estimate for compound 4 lay 1.7-fold (0.22 log units) above the measured number; measured number below the stated range.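

In this assay, the fluoro change on the core of compound 3 gives an at least 1.1-fold lower number from compound 3 to compound 4 (0.04 log units; that floor lies within the scatter). Set beside the same change on the core of compound 1, the comparison stays unresolved: the same change on two cores in this assay, an at least 1.7-fold higher number (0.24 log units; that floor lies within the scatter) from compound 1 to compound 2 and an at least 1.1-fold lower number (0.04 log units; that floor lies within the scatter) from compound 3 to compound 4; the limit leaves it open whether they differ. The two steps show neither that the change carries over between these cores with the same size and direction nor that it behaves differently, since neither printed floor lies beyond the scatter and both steps involve a limit: the limit of > 100000 nM in this assay, at which 2 of the 4 values shown sit.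

Left open is how an amine or a carboxylic acid in place of the fluoro group would read in this assay. Also open, as far as these compounds go, is how the change would read on a pair with both members clear of the limit.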